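The compounds below may be only part of what the source reports. "The series", "measured", "known", "first", "only" and "open" are said of these compounds alone.

The series shares one core, an amide linked to a sulfonamide, and differs in the groups at either end. Compound 1 `O=C(NS(=O)(=O)c1ccc(NC(=O)c2ccc(Cl)cc2Cl)cc1)c1ccccc1` belongs to it, and in a functional assay on HEK293 cells for agonist activity at probable G-protein coupled receptor 27 (Homo sapiens), read by a luciferase reporter and beta-arrestin recruitment, with a stated time of 10 min (on this read-out lower numbers stand for smaller maximal responses and higher numbers for larger maximal responses), compound 1 gives "not determined" (no result reported); compound 3 `O=C(Nc1ccc(S(=O)(=O)Nc2ccc(Cl)cc2)cc1)c1ccc(Cl)cc1Cl` belongs to it as well, and in this assay compound 3 gives "not determined" (no result reported), so for neither of these two was a number reported. Within the data shown here, compound 2 `Cc1cc(Cl)ccc1C(=O)Nc1ccc(S(=O)(=O)Nc2ccccc2)cc1` is therefore the only member with a result: in this assay compound 2 gives 123%, a maximal response above that of the reference, and with no second number there is nothing to rank it against.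

Compound 4 `O=C(Nc1ccc(S(=O)(=O)Nc2ccccc2)cc1)c1ccc(I)cc1F` is the next compound to be tested. It keeps the whole core of compound 2 and changes one piece: 2-fluoro-4-iodophenyl in place of 4-chloro-2-methylphenyl on a carbonyl carbon. Among the measured compounds shown here, no measured pair in this set shows what such a swap does, so the size of the step has to be guessed. Two aromatic groups of equal size exchange places, and the expectation is a step from compound 2 to compound 4 of a number 13 percentage points lower from compound 2 to compound 4 (beyond the scatter), within or close to the scatter. Compound 4 is thus expected to reach about 110% in this assay, between 65% and 150%.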

Compound 4, largest response reached (Emax), in percent of the reference or control that the assay uses: 36%
Beside the measured number, compound 4's estimate is 74 percentage points above it; measured number outside the range, below it.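

In this assay, among these compounds, putting 2-fluoro-4-iodophenyl in place of 4-chloro-2-methylphenyl on a carbonyl carbon gives a number 87 percentage points lower from compound 2 to compound 4 (beyond the scatter), the first step that can be read. It shows that the maximal response depends strongly on this aromatic group, even though the two groups have the same count of heavy atoms, the same ring and no hydrogen-bond donors or acceptors. No measurement here explains the drop.

Two things change at once, methyl to fluoro and chloro to iodo, so the compounds shown do not reveal which matters more; 4-iodo-2-methylphenyl or 4-chloro-2-fluorophenyl, each carrying only one of these changes, would separate the two. Also open, going by these compounds, is how a ring bearing an amine or a carboxylic acid at this place would behave.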